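Working notes on compound 4 against compound 3

The source may report more compounds than this note shows. Statements on the series, on what has been measured and on what is new or still open speak of the compounds shown alone.

Measured compounds:
compound 1, `COC(=O)Nc1cc(-c2ccc(OC[C@@](C)(N)CC(C)C)cn2)ccn1`: 18 nM
compound 2, `COC(=O)Nc1cc(-c2cnc(OC[C@@](C)(N)CC(C)C)c(Cl)c2)ccn1`: 0.11 nM
compound 3, `COC(=O)Nc1cc(-c2cc(Cl)c(OC[C@@](C)(N)CC(C)C)cn2)ccn1`: 0.11 nM

In an assay on brain (strain C57BL6) for displacement of a labelled ligand from AP2-associated protein kinase 1 (Mus musculus), read by scintillation counting, with a stated time of 1 h (a higher number here means a weaker inhibitor, a lower number a stronger inhibitor), compound 3 stands level with compound 2 at the digits shown, and the two together give the lowest numbers of the three. Within the data shown here, compound 1 is the outlier, and the gap to it is the only measured single-point step in the set: a 160-fold lower number from compound 1 to compound 3 (2.21 log units; beyond the scatter), chloro in place of hydrogen on an aromatic carbon. Between compound 2 and compound 3 no single step is defined; their two values simply read the same at the digits shown.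

Compound 4, `COC(=O)Nc1cc(-c2cc(C)c(OC[C@@](C)(N)CC(C)C)cn2)ccn1`, differs from compound 3 by methyl in place of chloro on an aromatic carbon. Among the measured compounds shown here, no measured pair shows a methyl at this carbon, so the step from chloro to methyl has no direct precedent here. The step from compound 1 to compound 3 only shows that filling this carbon with chloro rather than hydrogen matters a great deal; it does not show how chloro and methyl compare. The working expectation is that compound 4 keeps most of what compound 3 shows, with a modest loss more likely than a gain, so the expected step is a 2.7-fold higher number from compound 3 to compound 4 (0.44 log units; beyond the scatter). Compound 4 is estimated at 0.3 nM, with a range from 0.08 nM to 1.5 nM expected in this assay.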

Compound 4, inhibition constant: 1.4 nM
For compound 4 the middle estimate is 4.7-fold (0.67 log units) below the measured one, and the stated range covers the measured number.
By their numbers in this assay, from the lowest: compounds 2 and 3 (each within the scatter of the next); then compound 4; then compound 1.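

In this assay, methyl on this aromatic carbon, ortho to the (2-amino-2,4-dimethylpentyl)oxy group and opposite the ring nitrogen, gives a 13-fold lower number from compound 1 to compound 4 (1.11 log units; beyond the scatter) and so shows that the large gain over hydrogen is not confined to chloro. The two groups are still far from interchangeable at this carbon: methyl in place of chloro gives a 13-fold higher number from compound 3 to compound 4 (1.10 log units; beyond the scatter) even though each group counts a single heavy atom, so the identity of the group matters as well as the filling of the carbon. No measurement on hand bears on what separates chloro from methyl here, and the series offers no explanation for the difference.

Still open, from the compounds shown here alone, is how other small groups at this carbon, such as fluoro, bromo, methoxy or nitrile, would rank against chloro and methyl in this assay. Also open is whether methyl in place of chloro would give a step of similar size at the chlorine-bearing carbon of compound 2, since no methyl counterpart of that compound appears among those shown.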